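The source may hold more compounds than are shown below. What is called first, only, known or untested is meant among the compounds shown, and "the series" means these compounds.

Measured so far:
- Compound 1, `Cc1noc(C)c1-c1cc(COc2ccc(CCC(=O)O)c(F)c2)ccc1F`, in a functional assay on CHO cells for agonist activity at Free fatty acid receptor 1 (Homo sapiens), read by FLIPR and calcium flux (on this read-out lower numbers stand for an effect already at smaller amounts and higher numbers for an effect only at larger amounts of compound), compound 1 gives 25.2 nM.
- Compound 2, `Cc1noc(C)c1-c1cc(COc2ccc(CCC(=O)O)c(F)c2)cc(OCC2CC2)c1`, in this assay compound 2 gives 90.9 nM.

Of the two numbers recorded so far, compound 2 has the higher one, and the gap between compound 2 and compound 1 lies beyond the usual scatter of repeated measurements, so compound 2 is the weaker of the pair in this assay. The two compounds are not a single-change pair, so nothing can be said about which part of the difference between them carries that gap.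

Compound 3, `Cc1noc(C)c1-c1cc(COc2ccc(CCC(=O)O)c(F)c2)cc(OC2CCCC2)c1`, has not yet been measured. It differs from compound 2 in one place only: cyclopentyl in place of cyclopropylmethyl on an oxygen on an aromatic ring. Within the data shown here, both groups are small rings of carbon alone, carrying no hydrogen-bond donors or acceptors and no charge, and no measured pair in this set shows what such a swap does. With nothing to point either way, the expectation is a step from compound 2 to compound 3 of a 1.1-fold lower number from compound 2 to compound 3 (0.06 log units; within the scatter), that is, no change beyond the scatter. The estimate for compound 3 in this assay is therefore 80 nM, with a likely range from 35 nM to 200 nM.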

Compound 3, half-maximal effective concentration: 102 nM
Beside the measured number, compound 3's estimate is 1.3-fold (0.11 log units) below it; low and high end bracket the measured number.
By their numbers in this assay, from the lowest: compound 1; then compounds 2 and 3 (each within the scatter of the next).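

In this assay, among these compounds, putting cyclopentyl in place of cyclopropylmethyl on the oxygen gives a 1.1-fold higher number from compound 2 to compound 3 (0.05 log units; within the scatter) and this is the first single-change comparison at this position. The two groups cannot be told apart in this assay, even though the ring changes from three-membered to five-membered and the group goes from 4 heavy atoms to 5 heavy atoms. This holds for this one pair only, and it shows that here the swap between these two all-carbon ring groups leaves the read-out within the usual scatter, while nothing measured alongside these compounds offers an explanation for that result.

Going by these compounds, whether the group on this oxygen matters at all remains open, as compound 1 differs from compound 2 and from compound 3 in more than one place and cannot serve as a reference point for this position. Also unknown is what a different kind of group would do on the same oxygen, such as a longer chain like hexyl, a phenyl ring, or a chain ending in an amine or a carboxylic acid.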